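The source may hold more compounds than are shown below. What is called first, only, known or untested is meant among the compounds shown, and "the series" means these compounds.

Compound 1 `O=C(CCCCCc1ccccc1)c1nc2cccnc2o1` in an assay on HEK-293T cells for inhibition of diacylglycerol lipase-alpha (Homo sapiens), read by colorimetric assay (a lower number here means a stronger inhibitor, a higher number a weaker inhibitor), gives 1700 nM. Compound 2 `O=C(CCCCCCc1ccccc1)c1nncs1` sits at a limit of the assay in this assay, > 10000 nM. Compound 3 `O=C(CCCCCCc1ccccc1)c1nnc(-c2cccs2)s1` likewise sits at a limit in this assay, > 10000 nM. The step that the two limits leave unreadable from compound 2 to compound 3 cannot be sized, as both values rest on (the limit of > 10000 nM in this assay, at which 2 of the 3 values shown sit). Compound 4 `COc1coc(C(=O)CCCCCCc2ccccc2)n1` differs from compound 2 by 4-methoxy-1,3-oxazol-2-yl in place of 1,3,4-thiadiazol-2-yl on a carbonyl carbon. Going by the values given here, no measured step bears directly on this change; the only value read as a number belongs to compound 1, which carries a different ring on the carbonyl carbon. Given that compound 1 gives 1700 nM, compound 4 is expected in this assay at about 2000 nM, with a range from 400 nM to 10000 nM. The step of an at least 5.0-fold lower number from compound 2 to compound 4 (0.69 log units; beyond the scatter) is accordingly expected to lead out of the limit region.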

Compound 4, half-maximal inhibitory concentration: > 10000 nM
Compound 4: no number, only a limit; the forecaster's own chance of this, stated with the estimate: 20%; middle value at least 5.0-fold (0.69 log units) from the limit.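

Going by these compounds alone, compound 4 sits at a limit of the assay, > 10000 nM, so no step between compound 2 and compound 4 can be read: the limit of > 10000 nM in this assay, at which 3 of the 4 values shown sit. Left open is how 1,3,4-thiadiazol-2-yl and 4-methoxy-1,3-oxazol-2-yl compare on a carbonyl carbon in this assay.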